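Swapping the 2,3-dimethylphenyl group of compound 2

A few compounds are considered here, and "the series" means these few. Any claim that something is new, unique, unknown or untested is made for them only; others in the source may bear on it.

In a functional assay on the whole organism for agonist activity, with Mus musculus as the target (a higher number here means that more compound is needed for the effect, a lower number that less compound is needed), compound 1 `Cc1c(Cl)cccc1N1CCN(CCCCOc2ccc3ccc(O)nc3c2)CC1` gives 20.1 umol/kg while compound 2 `Cc1cccc(N2CCN(CCCCOc3ccc4ccc(O)nc4c3)CC2)c1C` gives 3.9 umol/kg and holds the lower of the two numbers. For the measured compounds named here, compound 3 `CCOc1ccccc1N1CCN(CCCCOc2ccc3ccc(O)nc3c2)CC1` has 2-ethoxyphenyl in place of 2,3-dimethylphenyl on an amine nitrogen in a ring as its one change. Going by the values given here, only one measured step bears on this, the modest 5.2-fold lower number from compound 1 to compound 2 (0.71 log units; beyond the scatter) with methyl in place of chloro, and it suggests a size but no direction. The expected change is a 2.3-fold higher number from compound 2 to compound 3 (0.36 log units; beyond the scatter) in this estimate, tentatively upward and smaller than that measured step. For compound 3 the estimate is 9 umol/kg within an expected range of 2.5 umol/kg to 32 umol/kg overall.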

Compound 3, dose for half-maximal effect: > 20 umol/kg
Compound 3: a limit, no number (the forecaster's own chance of this, stated with the estimate: 3%); middle value at least 2.2-fold (0.34 log units) away from the limit.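

In this assay, 2-ethoxyphenyl in place of 2,3-dimethylphenyl on the amine nitrogen in a ring gives an at least 5.1-fold higher number from compound 2 to compound 3 (0.70 log units; beyond the scatter), so this position responds to more than the methyl-for-chloro swap already seen. Compound 3 gives a limit and not a number: the limit of > 20 umol/kg in this assay, at which 1 of the 3 values shown sits. The step from compound 1 to compound 3 cannot be read against that limit.

The compounds shown leave open whether the ether oxygen, the ethyl group or the missing methyl carries the step. 2-Methoxyphenyl and 2-ethylphenyl on the same nitrogen would bear on this.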